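Replacing the 4-chlorophenyl group in compound 2

The source may hold more compounds than are shown below. What is called first, only, known or untested is meant among the compounds shown, and "the series" means these compounds.

Measured so far in an ADME assay on Caco-2 cells (Homo sapiens) for permeability, read by LC-MS, with a stated time of 2 h (a higher number here means that the compound crosses the layer faster, a lower number that the compound crosses the layer more slowly), are these values

- compound 1 `CCCN(Cc1ccc(OCCn2c(=O)ccn(C)c2=O)c(C)c1)C(CC(=O)O)c1ccc(Cl)cc1` gives 3.2 nm/s
- compound 2 `CCCN(Cc1ccc(OCCn2c(=O)ccn(C)c2=O)c(OC)c1)C(CC(=O)O)c1ccc(Cl)cc1` gives 1 nm/s
- compound 3 `COc1cc(CN(CC2CC2)C(CC(=O)O)c2ccc(Cl)cc2)ccc1OCCn1c(=O)ccn(C)c1=O` gives 0.8 nm/s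

Compound 2 lies within the scatter of compound 3, the gap being a 1.3-fold lower number from compound 2 to compound 3 (0.10 log units; within the scatter) on this pair. Compound 1 stands clear of it, with a 3.2-fold lower number from compound 1 to compound 2 (0.51 log units; beyond the scatter) as the measured step. Compound 4 `CCCN(Cc1ccc(OCCn2c(=O)ccn(C)c2=O)c(OC)c1)C(CC(=O)O)c1ccc2c(c1)CCO2` keeps the rest of compound 2 and loses its 4-chlorophenyl, with a group of 9 heavy atoms (8 carbon, 1 oxygen; one five-membered non-aromatic ring with 1 hetero atom, one six-membered aromatic ring of carbon only) in place of a group of 7 heavy atoms (6 carbon, 1 chlorine; one six-membered aromatic ring of carbon only), on a saturated chain carbon bound to an amine nitrogen and a saturated chain carbon as the difference. Neither measured step changes that group, so they offer only a loose guide to size and none to direction. The expected change is a 1.3-fold lower number from compound 2 to compound 4 (0.10 log units; within the scatter) and no clear move beyond the scatter is expected. The estimated value for compound 4 is 0.8 nm/s with 0.3 nm/s to 2.2 nm/s as its expected range.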

Compound 4, apparent permeability: 2 nm/s
Estimate against measurement, compound 4: 2.5-fold (0.40 log units) below, and the stated range covers the measured number.
By their numbers in this assay, from the lowest: compounds 3, 2, 4 and 1 (each within the scatter of the next, the first and the last beyond it).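

For the compounds shown here, all the earlier compounds carry 4-chlorophenyl at the saturated chain carbon bound to an amine nitrogen and a saturated chain carbon, so this pair alone tests that place. In this assay, the exchange for the oxygen-containing group gives a 2.0-fold higher number from compound 2 to compound 4 (0.30 log units; within the scatter), showing that a group with an added five-membered non-aromatic ring can stand there in place of 4-chlorophenyl with no step beyond the scatter. No measurement shown accounts for this result. Open, as far as these compounds go, is how an unsubstituted phenyl or a pyridine ring would read at this place. Also open, from the compounds shown here alone, is whether the entering group would give a similar number alongside methyl instead of methoxy on the aromatic carbon.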